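A few compounds are considered here, and "the series" means these few. Any claim that something is new, unique, unknown or untested is made for them only; others in the source may bear on it.

Three compounds have been measured so far in an ADME assay on MDBK cells (Bos taurus) for cytotoxicity, read by MTT assay (on this read-out higher numbers stand for lower toxicity in this test and lower numbers for higher toxicity in this test), as follows

- Compound 1 `Cc1ccc(C(C)C)c(OCCCCCCN2C[C@H](O)[C@@H](O)[C@H](O)[C@H]2CO)c1` gives 62000 nM
- Compound 2 `CCCC1CCCCC1OCCCCCCN1C[C@H](O)[C@@H](O)[C@H](O)[C@H]1CO` gives 150000 nM
- Compound 3 `OC[C@@H]1[C@@H](O)[C@H](O)[C@@H](O)CN1CCCCCCOc1cccc(C(F)(F)F)c1` gives > 500000 nM (a limit of the assay, not a number)

Among the two true numbers, compound 2 stands highest at 150000 nM in this assay and lies beyond the usual scatter from compound 1, its nearest neighbour.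

Compound 4 `COc1ccc(OCCCCCCN2C[C@H](O)[C@@H](O)[C@H](O)[C@H]2CO)cc1` keeps the rest of compound 2 but places a 4-methoxyphenyl group, with its six-membered aromatic ring of carbon only, on an oxygen on a saturated carbon, where compound 2 has a six-membered non-aromatic ring of carbon only a group of 8 heavy atoms (7 carbon, 1 oxygen; one six-membered aromatic ring of carbon only) in place of a group of 9 heavy atoms (9 carbon; one six-membered non-aromatic ring of carbon only), on an oxygen on a saturated carbon in the same spot.

Within the data shown here, no measured pair differs in one place only, so the forecast is uncertain. Compound 3 also has an aromatic ring on that oxygen, and its > 500000 nM is a limit. Compound 1 goes against any simple rule, since it too has an aromatic ring there yet gives 62000 nM as a lower number than compound 2.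

A modest rise in this assay is therefore expected, towards lower toxicity. The estimated change is a 1.7-fold higher number from compound 2 to compound 4 (0.24 log units; within the scatter) in this forecast. For compound 4 the expected value is 260000 nM with an estimated range from 110000 nM to 600000 nM in this test.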

Compound 4, half-maximal cytotoxic concentration: > 500000 nM
Compound 4: no number, only a limit; the forecaster's own chance of this, stated with the estimate: 35%; middle value at least 1.9-fold (0.28 log units) away from the limit.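

In this assay, among these compounds, putting a 4-methoxyphenyl group in place of the saturated ring group, on an oxygen on a saturated carbon, gives an at least 3.3-fold higher number from compound 2 to compound 4 (0.52 log units; beyond the scatter), which is the first comparison here that changes this spot alone and lies beyond the usual scatter. Compound 4 gives > 500000 nM, which is a limit of the assay and not a number. The step therefore sets only a minimum size for this change and does not give its full size, because compound 4 sits at a limit that it shares with compound 3: the limit of > 500000 nM in this assay, at which 2 of the 4 values shown sit.

Compound 1, which also carries an aromatic ring on that oxygen, gives 62000 nM, so the presence of an aromatic ring alone does not settle the value in this test. The compounds shown leave open whether the methoxy group on the ring of compound 4 matters, which a plain phenyl group in the same spot could test, and whether a ring bearing an amine or a carboxylic acid would give a true number rather than a limit.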